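The source may report more compounds than this note shows. Statements on the series, on what has been measured and on what is new or still open speak of the compounds shown alone.

Measured so far in a physicochemical assay for solubility, in phosphate buffer, at pH 7.4; on this read-out lower numbers stand for lower solubility and higher numbers for higher solubility:
compound 1 `CCOC(=O)c1c(-c2ccc(C(F)(F)F)cc2)[nH]c2cccc(OC)c2c1=O` gives 22000 nM
compound 2 `CCOC(=O)c1c(-c2ccc(C(C)(C)C)cc2)[nH]c2cccc(OC)c2c1=O` gives 1000 nM
compound 3 `CCOC(=O)c1c(-c2ccc(C(C)(C)C)cc2)[nH]c2cc(OC)ccc2c1=O` gives 2000 nM

Compound 4 `CCOC(=O)c1c(-c2ccc(C(F)(F)F)cc2)[nH]c2cc(OC)ccc2c1=O` is not yet measured. The change from compound 2 to compound 1 is trifluoromethyl in place of tert-butyl on an aromatic carbon; it made a step of a 22-fold higher number from compound 2 to compound 1 (1.34 log units; beyond the scatter) in this assay. The change from compound 3 to compound 4 is trifluoromethyl in place of tert-butyl on an aromatic carbon, the same change. The difference between the core of compound 2 and the core of compound 3 is not broken down here; in this assay their values differ within the scatter.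

The step from compound 3 to compound 4 in this assay is expected to be of similar size, a 20-fold higher number from compound 3 to compound 4 (1.30 log units; beyond the scatter), because the same change made a 22-fold higher number from compound 2 to compound 1 (1.34 log units; beyond the scatter). Compound 4 is therefore estimated at 40000 nM in this assay, with a range from 15000 nM to 100000 nM, resting on one earlier step only.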

Compound 4, solubility: 8000 nM
Compound 4: middle estimate off by 5.0-fold (0.70 log units), on the high side; measured number outside the range, below it.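

In this assay trifluoromethyl in place of tert-butyl on an aromatic carbon gave a 22-fold higher number from compound 2 to compound 1 (1.34 log units; beyond the scatter) on one core and a 4.0-fold higher number from compound 3 to compound 4 (0.60 log units; beyond the scatter) on the other. The direction therefore carried across these two cores, while the size did not: a large step on the first became a modest one on the second. Two pairs give no rule for a third core, and nothing at hand bears on why the two steps differ in size.

Still open, going by these compounds, is how a nitrile or a carboxylic acid would compare with trifluoromethyl and tert-butyl at this place on either core. Also open, on these data alone, is whether the same change keeps its direction on a core carrying an amine in place of the methoxy group.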